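A few compounds are considered here, and "the series" means these few. Any claim that something is new, unique, unknown or untested is made for them only; others in the source may bear on it.

In a functional assay on DU-145 cells (Homo sapiens) for cytotoxicity, read by MTT assay (on this read-out lower numbers stand for stronger inhibition and higher numbers for weaker inhibition), compound 1 `COc1ccc2cc([C@H](C)c3nnc(SCc4ccc(Cl)cc4)n3-c3ccc(F)cc3)ccc2c1` gives 57400 nM, the only numeric result so far. Compound 2 `COc1cccc(CSc2nnc([C@@H](C)c3ccc4cc(OC)ccc4c3)n2-c2ccc(Cl)cc2)c1` stands only at a limit, <= 400000 nM, and has no exact value. Compound 3 `COc1ccc2cc([C@H](C)c3nnc(SCc4ccc(C)cc4)n3-c3ccc(Cl)cc3)ccc2c1` has 4-methylphenyl in place of 3-methoxyphenyl on a saturated chain carbon bound to a sulfur. Among the measured compounds shown here, with no measured step to draw on, the expectation leans on compound 1 at 57400 nM. The expected step that the limit leaves unreadable from compound 2 to compound 3 in this assay points towards stronger inhibition, though its size is loose when measured against a limit. For compound 3 the estimate is 60000 nM, with an expected range of 15000 nM to 250000 nM.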

Compound 3, half-maximal inhibitory concentration: 18800 nM
Compound 3: the middle estimate sits 3.2-fold (0.50 log units) above what was measured; low and high end bracket the measured number.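

No step from compound 2 to compound 3 can be read, because compound 2 stands only at a limit: the limit of <= 400000 nM in this assay, at which 1 of the 3 values shown sits.

The compounds shown leave open how far 4-methylphenyl and 3-methoxyphenyl on a saturated chain carbon bound to a sulfur differ in effect.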